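Adding a hydroxy group to a core that shows no cytotoxicity

The source may report more compounds than this note shows. Statements on the series, on what has been measured and on what is new or still open speak of the compounds shown alone.

Measured compounds:
compound 1 `C[C@@H]1C(=O)[C@H]2C[C@]1(O)CC1=C2[C@]2(C)CCC[C@](C)(CO)[C@H]2CC1` gives > 50000 nM
compound 2 `C[C@@H]1C(=O)[C@H]2C[C@]1(O)CC1=C2[C@]2(C)CCCC(C)(C)[C@H]2CC1` gives > 50000 nM

Both values come from a functional assay on PC-3 cells (Homo sapiens) for cytotoxicity, read by MTT assay, with a stated time of 24 h; a higher number here means a weaker inhibitor, a lower number a stronger inhibitor. For compound 1 the value > 50000 nM is a limit of the assay and not a number. For compound 2 the value > 50000 nM is likewise only a limit. Compound 2 therefore stands at the edge of what this assay can report, and the step that the two limits leave unreadable from compound 1 to compound 2 cannot be sized, because both of its ends sit at the limit of > 50000 nM in this assay, at which 2 of the 2 values shown sit.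

Compound 3 `C[C@@H]1C(=O)[C@H]2C[C@]1(O)CC1=C2[C@]2(C)CCC[C@@](C)(CO)[C@H]2CC1` differs from compound 2 by hydroxy in place of hydrogen on a saturated chain carbon bound to a saturated ring carbon. For the measured compounds named here, the only measured step that touches this kind of change is the one from compound 1 to compound 2, and it is unreadable, so no direction or size of change can be taken from the data. With both measured compounds at the limit, the step that the limit leaves unreadable from compound 2 to compound 3 for compound 3 is expected to stay within what the assay cannot resolve. Compound 3 is estimated at 80000 nM, with a range from 30000 nM to 300000 nM, most likely reported again as a limit.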

Compound 3, half-maximal inhibitory concentration: > 50000 nM
Compound 3 was reported as a limit; the forecaster's own chance of this, stated with the estimate: 85%; the middle value does not contradict the limit.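

In this assay compound 3 gives > 50000 nM, which is a limit and not a number. No step among compound 1, compound 2 and compound 3 can be read, because all of them stop at the same edge: the limit of > 50000 nM in this assay, at which 3 of the 3 values shown sit.

The compounds shown leave open whether the hydroxy group, or the configuration that separates compound 1 from compound 3, changes cytotoxicity at all.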